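Opening the Ring: From Compound 3 to Compound 4

The source may hold more compounds than are shown below. What is called first, only, known or untested is meant among the compounds shown, and "the series" means these compounds.

Three compounds share one core and differ in the groups attached to it. Compound 1 `CCC(COC)N(C)c1nc(C)nc2c1nnn2-c1ccc(C(C)C)cc1Br` gives 11.2 nM in an in vitro assay on 293-EBNA cells for binding affinity to corticotropin-releasing factor receptor 1 (Homo sapiens); a higher number here means a weaker inhibitor, a lower number a stronger inhibitor. Compound 2 `CCCC(CCC)Nc1nc(C)nc2c1nnn2-c1ccc(Br)cc1Br` gives 0.8 nM in this assay. Compound 3 `Cc1nc(N2CCCC2)c2nnn(-c3ccc(C(C)C)cc3Br)c2n1` gives 194 nM in this assay. Compound 3 thus sits at the weak end of the three: its number is the highest, with compound 1 the nearest and compound 2 the furthest away.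

Compound 4 `CCN(CC)c1nc(C)nc2c1nnn2-c1ccc(C(C)C)cc1Br` has not been measured. It differs from compound 3 in one place: diethylamino in place of pyrrolidin-1-yl on an aromatic carbon. The entering group has no ring, and the leaving group is the only pyrrolidin-1-yl among the three measured compounds. Among the measured compounds shown here, one measured step bears on this: a 17-fold higher number from compound 1 to compound 3 (1.24 log units; beyond the scatter), in which a group with no ring gave way to that ring. Compound 4 runs the other way, although the group it gains is not the group compound 1 carries. Compound 4 is therefore expected to give a lower number than compound 3 in this assay, a step of a 4.9-fold lower number from compound 3 to compound 4 (0.69 log units; beyond the scatter), though probably not all the way back to compound 1. The estimate for compound 4 is 40 nM, with a range from 10 nM to 160 nM.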

Compound 4, inhibition constant: 25.3 nM
Compound 4: middle estimate off by 1.6-fold (0.20 log units), on the high side, and the stated range covers the measured number.
By their numbers in this assay, from the lowest: compound 2; then compound 1; then compound 4; then compound 3.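

Pyrrolidin-1-yl and diethylamino have the same heavy-atom and hydrogen-bond acceptor counts, so this change mainly isolates the presence of the ring, and in this assay opening it gives a 7.7-fold lower number from compound 3 to compound 4 (0.88 log units; beyond the scatter). Among the groups without a ring at this aromatic carbon, the larger group of compound 1 still holds an edge, with a 2.3-fold higher number from compound 1 to compound 4 (0.35 log units; beyond the scatter), so removing the ring does not account for the whole gap. No measurement here gives a cause for either step.

The compounds shown leave open whether a piperidin-1-yl ring would behave like pyrrolidin-1-yl and whether a longer chain, as in dipropylamino, would lower the number further. They also do not separate the effect of the oxygen in compound 1 from that of its extra carbons, which an all-carbon chain of matching length could address.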